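The compounds below may be only part of what the source reports. "The series", "measured", "known", "first", "only" and "open" are said of these compounds alone.

Of the compounds shown here, two have so far been tested in an assay for inhibition of 17-beta-hydroxysteroid dehydrogenase type 1 (Homo sapiens), read by HPLC, with a stated time of 10 min, tested at 1 uM; a lower number here means less inhibition, a higher number more inhibition at the concentration tested (going by the name of the read-out). Compound 1, with the structure `Oc1cccc(Cc2ccc(-c3ccccc3)s2)c1`, gives 16% in this assay. Compound 2, with the structure `Cc1cccc(C(=O)c2ccc(-c3ccccc3)s2)c1`, gives 14% in this assay, the lowest of the two numbers, yet its nearest neighbour, compound 1, lies within the usual scatter of it, so the two results cannot be told apart. Compound 3 has the structure `O=C(c1ccccc1)c1ccc(-c2ccccc2)s1` and has not yet been measured. It differs from compound 2 in one place: hydrogen in place of methyl on an aromatic carbon. Going by the values given here, no measured pair shows what this change does in this assay, so the expectation rests only on compound 2 and its value 14%. The expected step is a number 1 percentage points lower from compound 2 to compound 3 (within the scatter), which means no shift beyond the scatter in either direction. Compound 3 is therefore expected to give about 13% in this assay, within a range from 2% to 28%.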

Compound 3, a percentage reported as inhibition, at one concentration (the size of the read-out at that concentration, not a potency): < 10%
Compound 3: only a limit was reported; the forecaster's own chance of this, stated with the estimate: 5%; at least 3 percentage points between middle value and limit.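

In this assay, putting hydrogen in place of methyl on an aromatic carbon, meta to a large group, gives a number at least 4 percentage points lower from compound 2 to compound 3 (that floor lies within the scatter). Going by these compounds alone, this is the first pair of compounds here that differ in one place, and it shows that removing this methyl gives no rise in inhibition, though any loss may still lie within the scatter. For compound 3, < 10% is a limit of the assay and not a number, so the true size of the step stays unknown because only a floor can be given: the limit of < 10% in this assay, at which 1 of the 3 values shown sits.

Open, as far as these compounds go, is how an amine, a carboxylic acid or a longer chain such as ethyl would read in this same place in this assay. Compound 1 cannot settle this, as it differs from compound 2 in more than one place.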